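Swapping a carbamoyl group for a ring on compound 2

A few compounds are considered here, and "the series" means these few. Any claim that something is new, unique, unknown or untested is made for them only; others in the source may bear on it.

Measured in a functional assay (Saphenous vein) for binding affinity, with Oryctolagus cuniculus as the target; a higher number here means weaker binding, a lower number tighter binding:
Compound 1 `Cc1noc(Cc2ccc3[nH]cc([C@H]4C[C@H](N(C)C)C4)c3c2)n1`: 7590 nM
Compound 2 `CN(C)[C@H]1C[C@H](c2c[nH]c3ccc(CC(N)=O)cc32)C1`: 16600 nM

Compound 2, at 16600 nM, holds the higher of the two numbers, so it binds more weakly than compound 1 at 7590 nM. The unmeasured compound 3 `CN(C)[C@H]1C[C@H](c2c[nH]c3ccc(CN4C(=O)CNC4=O)cc32)C1` keeps the core of compound 2 and changes a single group, where a ring takes the place of carbamoyl on a saturated chain carbon bound to an aromatic carbon: 2,5-dioxoimidazolidin-1-yl in place of carbamoyl on a saturated chain carbon bound to an aromatic carbon.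

Within the data shown here, only one measured step bears on this change. It is a 2.2-fold higher number from compound 1 to compound 2 (0.34 log units; beyond the scatter), in which carbamoyl replaced 3-methyl-1,2,4-oxadiazol-5-yl at that same place. Read in reverse, that step links a ring group there with the lower number. One step is thin evidence, and the 2,5-dioxoimidazolidin-1-yl ring is not the ring of compound 1. The expectation in this assay is therefore a small move toward lower numbers, perhaps none beyond the scatter. The estimated change is a 1.7-fold lower number from compound 2 to compound 3 (0.22 log units; within the scatter). For compound 3 the expected value is 10000 nM, with an estimated range from 3000 nM to 35000 nM.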

Compound 3, dissociation constant: 9330 nM
Beside the measured number, compound 3's estimate is 1.1-fold (0.03 log units) above it, within the range that was stated.
By their numbers in this assay, from the lowest: compounds 1, 3 and 2 (each within the scatter of the next, the first and the last beyond it).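

At this place, on a saturated chain carbon bound to an aromatic carbon, 2,5-dioxoimidazolidin-1-yl brings a five-membered ring and 7 heavy atoms where carbamoyl has no ring and 3 heavy atoms, yet this assay shows a 1.8-fold lower number from compound 2 to compound 3 (0.25 log units; within the scatter), so the larger group produces no difference that can be told from the scatter. Set against the other ring group, 3-methyl-1,2,4-oxadiazol-5-yl, the new ring gives a 1.2-fold higher number from compound 1 to compound 3 (0.09 log units; within the scatter), so these two rings cannot be told apart here either. The earlier step, a 2.2-fold higher number from compound 1 to compound 2 (0.34 log units; beyond the scatter), might have suggested that ring groups and carbamoyl fall on separate sides, but the new compound lies within the scatter of both and does not support such a split.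

On these data alone, whether an amine, a carboxylic acid or a longer chain carrying the carbamoyl at this place would shift the number beyond the scatter remains open. Nothing available here accounts for these numbers or for the small size of the steps.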